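The source may report more compounds than this note shows. Statements on the series, on what has been measured and on what is new or still open speak of the compounds shown alone.

Values in an ADME assay on HUVEC cells (Homo sapiens) for cytotoxicity, read by MTT assay, with a stated time of 72 h; on this read-out lower numbers stand for stronger inhibition and higher numbers for weaker inhibition:
- compound 1 `COc1cc(-c2nccn2C)cc(OC)c1OC`: "not determined" (no result reported)
- compound 2 `COc1cc(-c2nccn2S(=O)(=O)c2ccc(C)cc2)cc(OC)c1OC`: "not determined" (no result reported)
- compound 3 `COc1cc(-c2nccn2-c2ccc3[nH]ccc3c2)cc(OC)c1OC`: 46700 nM

Compound 1 has no single number to stand on, and compound 2 has none either. Going by the values given here, the series therefore offers one numeric anchor, compound 3 at 46700 nM, and no measured step between compounds.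

Still to be measured is compound 4 `COc1cc(-c2nccn2-c2ccc(C)cc2)cc(OC)c1OC`. The structural change is 4-methylphenyl in place of methyl on an aromatic nitrogen, with 4-methylphenyl in place of methyl on an aromatic nitrogen.

Without a number for compound 1, the size of this step in this assay cannot be read from the data. A modest step towards stronger inhibition is expected, but this remains a tentative expectation. The placement rests on compound 3 at 46700 nM, which also carries an aromatic ring system on that nitrogen. For compound 4, the expected value in this assay is 40000 nM, with an estimated range of 10000 nM to 100000 nM.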

Compound 4, half-maximal inhibitory concentration: > 100000 nM
Compound 4 ended at the assay's limit; the forecaster's own chance of this, stated with the estimate: 15%; middle value at least 2.5-fold (0.39 log units) away from the limit.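

In this assay compound 4 gives > 100000 nM, which is a limit of the assay and not a number. Going by these compounds alone, compound 1 has no single number either, so no step from compound 1 to compound 4 can be read. The compounds shown leave open how the group on the aromatic nitrogen affects the value.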